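Swapping Halogen Patterns on the Amide Aryl Group

This account rests on a few compounds, and the source may have more. Where it says the series, first, only, none or still open, it means among the compounds named here.

Three compounds share one core and differ only in the aryl group on the amide nitrogen. In an assay on isolated protein for inhibition of histone deacetylase 4 (Homo sapiens), with a stated time of 1 h (a lower number here means a stronger inhibitor, a higher number a weaker inhibitor), compound 3 `O=C(COc1ccc2cc(/C=C3/SC(=O)NC3=O)ccc2c1)Nc1c(F)cc(F)cc1Br` gives 1100 nM, the lowest of the three numbers. Compound 1 `COc1cccc(NC(=O)COc2ccc3cc(/C=C4/SC(=O)NC4=O)ccc3c2)c1` gives 1600 nM in this assay, and the step of a 1.5-fold lower number from compound 1 to compound 3 (0.16 log units; within the scatter) lies within the scatter. Compound 2 `O=C(COc1ccc2cc(/C=C3/SC(=O)NC3=O)ccc2c1)Nc1ccccn1` gives 17000 nM in this assay; the step of an 11-fold higher number from compound 1 to compound 2 (1.03 log units; beyond the scatter) is large, as is a 15-fold lower number from compound 2 to compound 3 (1.19 log units; beyond the scatter). Compound 4 `O=C(COc1ccc2cc(/C=C3/SC(=O)NC3=O)ccc2c1)Nc1ccc(Br)c(Br)c1` carries 3,4-dibromophenyl in place of 2-bromo-4,6-difluorophenyl on an amide-type nitrogen. This keeps a carbon-only aromatic ring bearing halogens, so it resembles a 1.5-fold lower number from compound 1 to compound 3 (0.16 log units; within the scatter) rather than an 11-fold higher number from compound 1 to compound 2 (1.03 log units; beyond the scatter). A step within the scatter, a 1.1-fold higher number from compound 3 to compound 4 (0.04 log units; within the scatter), is therefore expected in this assay. Compound 4 is estimated at 1200 nM, within a range from 450 nM to 3500 nM.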

Compound 4, half-maximal inhibitory concentration: 4900 nM
Compound 4: middle estimate off by 4.1-fold (0.61 log units), on the low side, and the stated range ends below it.
By their numbers in this assay, from the lowest: compounds 3 and 1 (each within the scatter of the next); then compound 4; then compound 2.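

Having a carbon-only aromatic ring with halogens on the amide nitrogen does not by itself fix the number, since moving to 3,4-dibromophenyl gives a 4.5-fold higher number from compound 3 to compound 4 (0.65 log units; beyond the scatter) and also a 3.1-fold higher number from compound 1 to compound 4 (0.49 log units; beyond the scatter) in the comparison with the methoxy-bearing ring. That ring still does better than pyridin-2-yl, with a 3.5-fold lower number from compound 2 to compound 4 (0.54 log units; beyond the scatter) placing compound 4 in the middle of the series. No measurement available here explains why the two halogen patterns differ. Still open, going by these compounds, is how a plain phenyl ring or a single chlorine would compare. So is whether an amine or a carboxylic acid on this ring would lower or raise the number.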